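A few compounds are considered here, and "the series" means these few. Any claim that something is new, unique, unknown or untested is made for them only; others in the source may bear on it.

Measured so far in an assay on isolated protein for agonist activity at Bile acid receptor (Homo sapiens), read by AlphaScreen, with a stated time of 30 min; on this read-out lower numbers stand for an effect already at smaller amounts and higher numbers for an effect only at larger amounts of compound:
compound 1 `CCc1ccccc1-n1nc(C)c2c1NC(=O)[C@H](C)S[C@@H]2c1ccc(Oc2ccccc2)cc1`: 1100 nM
compound 2 `Cc1ccccc1-n1nc(C)c2c1NC(=O)[C@H](C)S[C@@H]2c1ccc(-c2cc3ccccc3o2)cc1`: 1500 nM
compound 3 `COc1ccccc1-c1ccc([C@H]2S[C@@H](C)C(=O)Nc3c2c(C)nn3-c2ccccc2C)cc1`: 1100 nM

Compound 1 stands level with compound 3 at the digits shown, the two together at the low end of the three numbers; compound 2 lies within the scatter of both, so the three measured compounds cannot be ordered on these values. Within the data shown here, the only single-point step in the set, a 1.4-fold lower number from compound 2 to compound 3 (0.13 log units; within the scatter), exchanges the group on an aromatic carbon and stays within the scatter.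

Compound 4 `Cc1cccc(-n2nc(C)c3c2NC(=O)[C@H](C)S[C@@H]3c2ccc(Oc3ccccc3)cc2)c1` differs from compound 1 in one place: 3-methylphenyl in place of 2-ethylphenyl on an aromatic nitrogen. Among the measured compounds shown here, no measured pair varies the group on this aromatic nitrogen, so the step from compound 2 to compound 3 does not bear on it and there is no precedent in the set for the size or direction of such a change. With nothing in the data pointing either way, the working expectation is no step beyond the scatter, held with a wide range to cover the absence of any comparable step.

Compound 4 is therefore expected near 1300 nM in this assay, within 450 nM to 4000 nM. This estimate corresponds to an expected 1.2-fold higher number from compound 1 to compound 4 (0.07 log units; within the scatter).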

Compound 4, half-maximal effective concentration: 2400 nM
Beside the measured number, compound 4's estimate is 1.8-fold (0.27 log units) below it; the measured number falls inside the stated range.
By their numbers in this assay, from the lowest: compounds 1, 3, 2 and 4 (each within the scatter of the next, the first and the last beyond it).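

In this assay, among these compounds, the group on the aromatic nitrogen of the five-membered ring is varied for the first time, and a 2.2-fold higher number from compound 1 to compound 4 (0.34 log units; beyond the scatter) shows that this position is not indifferent to what it carries, although the step is modest. The change is not a single one: 2-ethylphenyl, with 8 heavy atoms, gives way to 3-methylphenyl, with 7, so the alkyl group and its numbered place on the phenyl ring change together, while the counts of hydrogen-bond donors, hydrogen-bond acceptors and net charge stay the same. No supporting data bear on the origin of this step.

The compounds shown do not separate the two parts of the change, and a 3-ethylphenyl group on this nitrogen, with the rest of compound 1 kept, would isolate the numbered place on the ring from the length of the alkyl group. Also open, as far as these compounds go, is how the position responds to groups of another kind, such as an unsubstituted phenyl or a phenyl bearing a carboxylic acid or an amine.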